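Swapping chloro for methyl on a weakly active pyrazolidinone

This account rests on a few compounds, and the source may have more. Where it says the series, first, only, none or still open, it means among the compounds named here.

Compound 1 `C=C1CN(C)N(c2ccc(Cl)cc2)C1=O` was examined in a functional assay on NALM-6 cells (Homo sapiens) for inhibition, read by MTT assay, with a stated time of 48 h (on this read-out lower numbers stand for stronger inhibition and higher numbers for weaker inhibition), where compound 1 gives 51900 nM. Among the two compounds measured so far, compound 1 stands at the higher number. Going by the values given here, the only comparison is compound 2 `C=C1C(=O)N(c2ccccc2)N(c2ccccc2)C1CC`, which in this assay gives 14900 nM, a lower number than compound 1 by a margin beyond the usual scatter. Compound 2 differs from compound 1 in more than one place, so its lower number cannot be tied to any single change.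

Compound 3 `C=C1CN(C)N(c2ccc(C)cc2)C1=O` has not yet been measured in this assay. It differs from compound 1 in one place: methyl in place of chloro on an aromatic carbon. Among the compounds with values here, with no single-change step available among the measured compounds, the size of this step is unknown. The author expects the step of a 1.1-fold higher number from compound 1 to compound 3 (0.03 log units; within the scatter) to be small, within or near the scatter, in either direction. For compound 3 the author therefore estimates a value in this assay of 55000 nM, with a range from 25000 nM to 120000 nM.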

Compound 3, half-maximal inhibitory concentration: 90100 nM
Beside the measured number, compound 3's estimate is 1.6-fold (0.21 log units) below it; the measured number falls inside the stated range.
By their numbers in this assay, from the lowest: compound 2; then compounds 1 and 3 (each within the scatter of the next).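

In this assay, methyl in place of chloro on the aromatic carbon gives a 1.7-fold higher number from compound 1 to compound 3 (0.24 log units; within the scatter), so the two groups are not told apart at this position on this read-out. This is the first step among the compounds shown that isolates a single place, since the earlier comparison differed in more than one. No measured evidence bears on why this swap leaves the reading within the scatter.

On these data alone, it remains open whether a group of another kind at this place, such as an amine, a carboxylic acid or a longer chain, would move the number beyond the scatter. Also open, as far as these compounds go, is which of the several differences between compound 1 and compound 2 goes with the lower number of compound 2.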